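Hexyl-triazole chromanone series: macrophage tolerance notes

This account rests on a few compounds, and the source may have more. Where it says the series, first, only, none or still open, it means among the compounds named here.

Measured so far:
- compound 2 `CCCCCCn1cc(COc2ccc3c(c2)OC(c2ccc(Br)cc2)CC3=O)nn1`: 20300 nM
- compound 1 `CCCCCCn1cc(COc2ccc3c(c2)OC(c2ccc(C(C)C)cc2)CC3=O)nn1`: "not determined" (no result reported)
- compound 3 `CC(C)c1ccc(/C=C/C(=O)c2ccc(OCc3cn(Cc4ccc(Br)cc4)nn3)cc2O)cc1`: "not determined" (no result reported)

Among the measured compounds shown here, in an ADME assay on cells (Macrophage) for cytotoxicity, read by resazurin assay, with a stated time of 48 h (a higher number here means that more compound is tolerated, a lower number that less compound is tolerated), compound 2 gives 20300 nM, and this is the only number in hand; in this assay compound 1 gives "not determined" (no result reported), and compound 3 gives "not determined" (no result reported), so nothing can be compared against compound 2 and no step between measured compounds exists.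

Compound 4 `CCCCCCn1cc(COc2ccc3c(c2)OC(c2ccc(OC)cc2)CC3=O)nn1` is next, and its difference from compound 2 is methoxy in place of bromo on an aromatic carbon. A reading for it does not yet exist.

For the measured compounds named here, with only one value known, the expectation for compound 4 rests on compound 2 alone, whose 20300 nM sets the anchor. The change is small and the series core is unchanged, so the step expected from compound 2 to compound 4 is a 1.2-fold higher number from compound 2 to compound 4 (0.09 log units; within the scatter), a move that is not expected to go beyond the scatter in either direction. Compound 4 is therefore estimated at 25000 nM, with a range from 10000 nM to 60000 nM, to be checked against the measurement when it comes.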

Compound 4, half-maximal cytotoxic concentration: 57500 nM
For compound 4 the middle estimate is 2.3-fold (0.36 log units) below the measured one; the measured number falls inside the stated range.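

Swapping 4-bromophenyl for 4-methoxyphenyl gives a 2.8-fold higher number from compound 2 to compound 4 (0.45 log units; beyond the scatter) in this assay and is the only step available in this series. It shows that this aromatic carbon, para to a large group, is not silent: with the shared core and the hexyl chain unchanged, this one exchange moves the number beyond the scatter, in the direction of more compound tolerated. No measured evidence on the compounds accounts for the step, so it stands as an observation without an explanation.

Going by these compounds, with a single pair, it remains open whether the size of this step carries over to other groups at the same place, such as an amine, a carboxylic acid or a hydroxyl. Equally open, on these data alone, is whether it would hold if a longer chain, such as octyl, replaced the hexyl chain.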